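A few compounds are considered here, and "the series" means these few. Any claim that something is new, unique, unknown or untested is made for them only; others in the source may bear on it.

Among the compounds with values here, compound 2 `Fc1cccc(-c2nc(Nc3ccc(Cl)cc3)c3cc(F)ccc3n2)c1` is one of only two compounds measured so far in a functional assay on U-937 cells (Homo sapiens) for cytotoxicity, read by MTT assay, with a stated time of 48 h; on this read-out higher numbers stand for weaker inhibition and lower numbers for stronger inhibition. Compound 2 gives 32700 nM, the lower of the two numbers, and the other compound, compound 1 `Fc1cccc(Nc2nc(-c3cccc(F)c3)nc3ccc(F)cc23)c1`, gives 42300 nM. The step of a 1.3-fold lower number from compound 1 to compound 2 (0.11 log units; within the scatter) lies within the scatter, so these two values cannot be told apart. Compound 3 `Nc1cccc(Nc2nc(-c3cccc(F)c3)nc3ccc(F)cc23)c1` has not yet been measured. It differs from compound 2 by 3-aminophenyl in place of 4-chlorophenyl on a nitrogen on an aromatic ring. Within the data shown here, the one measured step that bears on this position is a 1.3-fold lower number from compound 1 to compound 2 (0.11 log units; within the scatter), in which 4-chlorophenyl took the place of 3-fluorophenyl on the same nitrogen and the number barely moved. Nothing measured speaks for a sizeable shift here, so the expected step is a 1.2-fold higher number from compound 2 to compound 3 (0.09 log units; within the scatter), not beyond the scatter. Compound 3 is therefore estimated at 40000 nM, with a range from 13000 nM to 120000 nM.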

Compound 3, half-maximal inhibitory concentration: > 50000 nM
Compound 3 gave a limit, no number; the forecaster's own chance of this, stated with the estimate: 25%; middle value at least 1.2-fold (0.09 log units) away from the limit.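

For compound 3 the reading in this assay is a limit of the assay and not a number: the limit of > 50000 nM in this assay, at which 1 of the 3 values shown sits. The new steps are therefore only floors: an at least 1.5-fold higher number from compound 2 to compound 3 (0.18 log units; that floor lies within the scatter), and, for amino in place of fluoro on an aromatic carbon, an at least 1.1-fold higher number from compound 1 to compound 3 (0.07 log units; that floor lies within the scatter). Within the data shown here, the 3-aminophenyl is the first group on this nitrogen to carry a hydrogen-bond donor of its own, and it brought no lower number, but both floors lie within the scatter, so the true size of the change stays unknown.

From the compounds shown here alone, it remains open how other groups on the same nitrogen would read, such as 3-hydroxyphenyl or 3-carboxyphenyl. Also open, going by these compounds, is whether an amine on a longer chain, in place of the amino on that ring, would give a number rather than a limit.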